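The source may hold more compounds than are shown below. What is called first, only, known or untested is meant among the compounds shown, and "the series" means these compounds.

Compound 3 `COc1ccc(C(=O)/C=C/c2cc(-c3cc(OC)c(OC)c(OC)c3)n[nH]2)cc1OC` gives 15700 nM in a functional assay on A549 cells (Homo sapiens) for inhibition, read by sulforhodamine B assay, with a stated time of 48 h (a lower number here means that less compound is tolerated, a higher number that more compound is tolerated), the lowest of the two numbers recorded there. Compound 1 `COc1cc(-c2cc(/C=C/C(=O)c3ccc(N)cc3)[nH]n2)cc(OC)c1OC` gives 86500 nM in this assay. Compound 2 `COc1cc(-c2cc(/C=C/C(=O)c3ccc(Cl)c(Cl)c3)[nH]n2)cc(OC)c1OC` reaches only the limit of this assay, > 100000 nM. Compound 4 `COc1ccc(C(=O)/C=C/c2cc(-c3cc(OC)c(OC)c(OC)c3)n[nH]2)cc1` has not yet been measured; it differs from compound 3 by hydrogen in place of methoxy on an aromatic carbon. The measured steps each exchange the whole aryl group on the carbonyl carbon: a 5.5-fold lower number from compound 1 to compound 3 (0.74 log units; beyond the scatter), an at least 6.3-fold lower number from compound 2 to compound 3 (0.80 log units; beyond the scatter) and an at least 1.1-fold higher number from compound 1 to compound 2 (0.06 log units; that floor lies within the scatter). None of them removes a single methoxy, so they bear on the new step only loosely. A small change, probably toward a somewhat higher number, is expected, a 1.6-fold higher number from compound 3 to compound 4 (0.20 log units; within the scatter). Compound 4 is therefore estimated at 25000 nM, within 8000 nM to 80000 nM.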

Compound 4, concentration lethal to 50% of the cells: > 100000 nM
Compound 4: a limit, no number (the forecaster's own chance of this, stated with the estimate: 10%); at least 4.0-fold (0.60 log units) between middle value and limit.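

In this assay, going by these compounds alone, the earlier steps exchanged the whole aryl group, whereas taking one methoxy off the 3,4-dimethoxyphenyl group to leave 4-methoxyphenyl already gives an at least 6.3-fold higher number from compound 3 to compound 4 (0.80 log units; beyond the scatter). Compound 4 gives a limit, not a number, so this size is only a floor: the limit of > 100000 nM in this assay, at which 2 of the 4 values shown sit.
The change of methoxy for amino gives an at least 1.1-fold higher number from compound 1 to compound 4 (0.06 log units; that floor lies within the scatter), and the step that joins the two limits cannot be read.

From the compounds shown here alone, how far beyond the limit compound 4 lies remains open. Also open, going by these compounds, is how a hydroxy or ethoxy group at this position would compare with the methoxy of compound 3.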